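Fluoro for Methyl on the Pyrimidine of Compound 3

The source may hold more compounds than are shown below. What is called first, only, known or untested is meant among the compounds shown, and "the series" means these compounds.

Going by the values given here, compound 3 `Cc1cnc(-c2ccc(Cl)c(C(=O)NCC3(O)CCCCCC3)c2)nc1` gives 8 nM in a functional assay on HEK293 cells for antagonist activity at P2X purinoceptor 7 (Homo sapiens) (on this read-out higher numbers stand for weaker inhibition and lower numbers for stronger inhibition), the lowest of the three numbers measured so far. Compound 1 `O=C(NCC1(O)CCCC(F)(F)C1)c1cc(-c2ncc(F)cn2)ccc1Cl` gives 51 nM, and compound 2 `N#Cc1cccc(-c2ccc(Cl)c(C(=O)NCC3(O)CCCCCC3)c2)n1` gives 232 nM. Among the compounds with values here, the only step between measured compounds, a 29-fold lower number from compound 2 to compound 3 (1.46 log units; beyond the scatter), exchanged the entire group attached to the shared core rather than a single substituent. Compound 4 `O=C(NCC1(O)CCCCCC1)c1cc(-c2ncc(F)cn2)ccc1Cl` differs from compound 3 by fluoro in place of methyl on an aromatic carbon. Compound 1 carries the same 5-fluoropyrimidin-2-yl group as compound 4 but a different saturated ring, so its value bears on this step only loosely. Within the data shown here, no measured step isolates this change, so only a modest shift is expected, most likely toward a somewhat higher number. Compound 4 is therefore estimated at 20 nM, within 6 nM to 60 nM, a step of a 2.5-fold higher number from compound 3 to compound 4 (0.40 log units; beyond the scatter).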

Compound 4, half-maximal inhibitory concentration: 16 nM
The estimate for compound 4 lay 1.3-fold (0.10 log units) above the measured number; the range from low to high includes it.
By their numbers in this assay, from the lowest: compounds 3 and 4 (each within the scatter of the next); then compound 1; then compound 2.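

Fluoro and methyl cannot be told apart at this position (a 2.0-fold higher number from compound 3 to compound 4 (0.30 log units; within the scatter)), so 5-fluoropyrimidin-2-yl and 5-methylpyrimidin-2-yl serve equally well here. The large gain over 6-cyanopyridin-2-yl holds with either group (a 15-fold lower number from compound 2 to compound 4 (1.16 log units; beyond the scatter)), and the two pairs with this fluoro group show a modest effect of the saturated ring, 1-hydroxycycloheptyl replacing 3,3-difluoro-1-hydroxycyclohexyl (a 3.2-fold lower number from compound 1 to compound 4 (0.50 log units; beyond the scatter)). No supporting evidence is available to explain these results. Going by these compounds, whether chloro, methoxy or an amine at this position would give a similar number remains open.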